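The source may hold more compounds than are shown below. What is called first, only, known or untested is meant among the compounds shown, and "the series" means these compounds.

In a functional assay on PC-3 cells (Homo sapiens) for inhibition, read by MTT assay, with a stated time of 48 h (on this read-out lower numbers stand for stronger inhibition and higher numbers for weaker inhibition), three compounds that share one core have been measured, and they differ only in what sits on the sulfur. Compound 1 (`COc1ccc(-n2c(S)nnc2-c2cc(OC)c(OC)c(OC)c2)cc1`) gives no number, only a limit of the assay, > 60000 nM in this case. Compound 2 (`COc1ccc(-n2c(SC)nnc2-c2cc(OC)c(OC)c(OC)c2)cc1`) likewise gives only a limit, > 60000 nM again. Compound 3 (`COc1ccc(-n2c(SCc3ccc(C)cc3)nnc2-c2cc(OC)c(OC)c(OC)c2)cc1`) reads 56500 nM and is the only one of the three with a true number. Everything seen so far therefore lies close to the limit of > 60000 nM in this assay, at which 2 of the 3 values shown sit, and no compound stands clear of it.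

Methyl in place of hydrogen on the sulfur gives a step that the two limits leave unreadable from compound 1 to compound 2 while the 4-methylbenzyl group gives an at least 1.0-fold lower number from compound 1 to compound 3 (0.02 log units; that floor lies within the scatter) as well as an at least 1.0-fold lower number from compound 2 to compound 3 (0.02 log units; that floor lies within the scatter) so no step can be read as going beyond the scatter. Compound 4 (`COc1ccc(-n2c(SCc3ccc(F)cc3)nnc2-c2cc(OC)c(OC)c(OC)c2)cc1`) brings a change that none of these steps tests: fluoro in place of methyl on an aromatic carbon in which fluoro takes the place of methyl on an aromatic carbon, para to a large group.

With compound 3 at 56500 nM and no readable step beyond the scatter to go on, no shift beyond the scatter is expected in this assay in either direction. The expected move is a 1.1-fold lower number from compound 3 to compound 4 (0.05 log units; within the scatter) and it remains only an estimate. For compound 4 the estimated value is 50000 nM with an expected range from 20000 nM to 100000 nM and the assay may well report only a limit instead.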

Compound 4, half-maximal inhibitory concentration: 35000 nM
For compound 4 the middle estimate is 1.4-fold (0.15 log units) above the measured one; the range from low to high includes it.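

With fluoro in place of methyl on an aromatic carbon, para to a large group, this position now has its first pair of true numbers that differ in one place, and in this assay the change gives a 1.6-fold lower number from compound 3 to compound 4 (0.21 log units; within the scatter). From the compounds shown here alone, replacing the hydrogen on the sulfur with the whole 4-fluorobenzyl group, or the hydrogen on the chain carbon of the methyl group with 4-fluorophenyl, gives an at least 1.7-fold lower number from compound 1 to compound 4 (0.23 log units; that floor lies within the scatter) and an at least 1.7-fold lower number from compound 2 to compound 4 (0.23 log units; that floor lies within the scatter), and since each of these is only a floor, the true size of either step remains unknown. Neither the swap of one heavy atom for another nor the addition of the larger group therefore shows a change beyond the scatter, and the series as a whole stays close to the edge of what this read-out can report: the limit of > 60000 nM in this assay, at which 2 of the 4 values shown sit.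

Going by these compounds, whether an amine or a carboxylic acid on that aromatic carbon, or a longer chain on the sulfur in place of the benzyl group, would bring a value well clear of that limit stays open. With only methyl and fluoro to compare here, and those two within the scatter of each other, the compounds shown give no direction for this position.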